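Chloro for fluoro on the sulfur-linked ring

The compounds below may be only part of what the source reports. "The series", "measured", "known", "first", "only" and "open" are said of these compounds alone.

Measured so far:
compound 1 `Cc1ccc(SCc2ccc(/C=C/C(=O)Nc3ccccc3N)cc2)cc1`: 4.93%
compound 2 `COc1ccc(SCc2ccc(/C=C/C(=O)Nc3ccccc3N)cc2)cc1OC`: 49.5%
compound 3 `Nc1ccccc1NC(=O)/C=C/c1ccc(CSc2ccc(F)cc2)cc1`: 20.2%

In a functional assay on HCT-116 cells (Homo sapiens) for inhibition, read by CCK-8 assay, with a stated time of 72 h, tested at 8 uM (on this read-out lower numbers stand for less inhibition of growth and higher numbers for more inhibition of growth at the one concentration tested), compound 3 gives 20.2%, the second highest of the three numbers. Its nearest neighbour is compound 1, which in this assay gives 4.93%; the gap, a number 15.3 percentage points higher from compound 1 to compound 3 (beyond the scatter), is beyond the scatter. Compound 2 lies furthest away, giving 49.5% in this assay, and a number 29.3 percentage points lower from compound 2 to compound 3 (beyond the scatter) is beyond the scatter as well.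

Compound 4 `Nc1ccccc1NC(=O)/C=C/c1ccc(CSc2ccc(Cl)cc2)cc1` has not yet been measured. It differs from compound 3 in one place: chloro in place of fluoro on an aromatic carbon.

Going by the values given here, no measured step swaps one of these two single-atom groups for the other. The step that comes closest is a number 15.3 percentage points higher from compound 1 to compound 3 (beyond the scatter), a modest rise when fluoro replaced methyl at this same place. Swapping fluoro for chloro keeps the size of the group similar, so the expected change a number 4.8 percentage points higher from compound 3 to compound 4 (within the scatter) is small and may not exceed the scatter. Compound 4 is therefore expected to give about 25% in this assay, with a range from 8% to 45%.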

Compound 4, percent growth inhibition at one concentration: 3.27%
Beside the measured number, compound 4's estimate is 21.7 percentage points above it, outside the stated range (below it).
By their numbers in this assay, from the lowest: compounds 4 and 1 (each within the scatter of the next); then compound 3; then compound 2.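

In this assay, going by these compounds alone, the group on this ring carbon matters even when only one atom changes: a number 16.9 percentage points lower from compound 3 to compound 4 (beyond the scatter), so fluoro and chloro cannot be treated as interchangeable at this position. Chloro and methyl cannot be told apart here, with a number 1.7 percentage points lower from compound 1 to compound 4 (within the scatter), while a number 46.2 percentage points lower from compound 2 to compound 4 (beyond the scatter) shows that the 3,4-dimethoxyphenyl group stays well clear of the 4-chlorophenyl group. Nothing available here explains these differences.

As far as these compounds go, how a single methoxy group, a bromo group or an amine on this ring carbon would compare remains open, and so does whether the higher number of compound 2 needs both of its methoxy groups. From the compounds shown here alone, each number also comes from one concentration, so how these compounds compare across a range of concentrations is unknown.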